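Chloro-for-hydrogen on two purine-type cores against colon cells

A few compounds are considered here, and "the series" means these few. Any claim that something is new, unique, unknown or untested is made for them only; others in the source may bear on it.

In a functional assay on HT-29 cells (Homo sapiens) for cytotoxicity, read by sulforhodamine B assay, with a stated time of 48 h (on this read-out higher numbers stand for lower toxicity in this test and lower numbers for higher toxicity in this test), compound 1, `ClCc1cccc(Cn2cnc3c(Cl)ncnc32)c1`, gives only a limit of the assay, > 100000 nM. Compound 2, `ClCc1cccc(Cn2cnc3c(Cl)nc(Cl)nc32)c1`, also reaches only a limit in this assay, > 100000 nM. The change between them, (chloro in place of hydrogen on an aromatic carbon), gives a step that the two limits leave unreadable from compound 1 to compound 2, which rests on (the limit of > 100000 nM in this assay, at which 3 of the 3 values shown sit). Compound 3, `ClCc1ccccc1Cn1cnc2ncnc(Cl)c21`, carries a core that differs from that of compound 1 in a way not broken down here, and in this assay compound 3 likewise gives only a limit, > 100000 nM. Compound 4, `ClCc1ccccc1Cn1cnc2nc(Cl)nc(Cl)c21`, bears the same change as compound 2, (chloro in place of hydrogen on an aromatic carbon), and has not yet been measured. Because the step from compound 1 to compound 2 is unreadable at the limit of > 100000 nM in this assay, at which 3 of the 3 values shown sit, the step from compound 3 to compound 4 is expected to be a step that the limit leaves unreadable from compound 3 to compound 4. Compound 4 is therefore estimated to give about 150000 nM, most likely again only a limit.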

Compound 4, concentration lethal to 50% of the cells: > 100000 nM
Compound 4: a limit, no number (the forecaster's own chance of this, stated with the estimate: 85%); the middle value lies beyond the limit too.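

Compound 3 and compound 4 both give only a limit in this assay, so no step between them can be read: the limit of > 100000 nM in this assay, at which 4 of the 4 values shown sit.

The compounds shown leave open whether chloro in place of hydrogen on an aromatic carbon changes this read-out at all, on either core.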